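Aryl swap on the carbonyl carbon: compound 2 to compound 4

The source may report more compounds than this note shows. Statements on the series, on what has been measured and on what is new or still open speak of the compounds shown alone.

In a functional assay on SF-539 cells (Homo sapiens) for cytotoxicity, read by sulforhodamine B assay, with a stated time of 48 h, tested at 10 uM (a higher number here means a weaker effect of the compound at the concentration tested, a lower number a stronger effect), compound 2 `COc1cc(-c2cc(/C=C/C(=O)c3ccc(Cl)c(Cl)c3)[nH]n2)cc(OC)c1OC` gives 28%, the highest of the three measured numbers; compound 3 `COc1ccc(-c2cc(/C=C/C(=O)c3cc(OC)c(OC)c(OC)c3)[nH]n2)cc1OC` gives -85% and compound 1 `COc1cc(-c2cc(/C=C/C(=O)c3ccc(N)cc3)[nH]n2)cc(OC)c1OC` gives -93%, both well beyond the scatter below it. Compound 4 `COc1ccc(C(=O)/C=C/c2cc(-c3cc(OC)c(OC)c(OC)c3)n[nH]2)cc1` differs from compound 2 by 4-methoxyphenyl in place of 3,4-dichlorophenyl on a carbonyl carbon. Among the measured compounds shown here, the only measured step at this position, a number 121 percentage points higher from compound 1 to compound 2 (beyond the scatter), shows that bringing in 3,4-dichlorophenyl raised the number sharply. Compound 4 removes that group for a methoxy-bearing aryl, and compound 3, which also carries a methoxy-bearing aryl on the carbonyl carbon though it differs elsewhere too, sits low. A large fall is therefore expected, a number 88 percentage points lower from compound 2 to compound 4 (beyond the scatter). Compound 4 is estimated at -60%, between -105% and 5%.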

Compound 4, a percentage reported as activity, at one concentration (the size of the read-out at that concentration, not a potency): -92%
Estimate against measurement, compound 4: 32 percentage points above; the range from low to high includes it.
By their numbers in this assay, from the lowest: compounds 1, 4 and 3 (each within the scatter of the next); then compound 2.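

On the carbonyl carbon, 4-methoxyphenyl in place of 3,4-dichlorophenyl gives a number 120 percentage points lower from compound 2 to compound 4 (beyond the scatter) in this assay, so the high number of compound 2 depends on the 3,4-dichlorophenyl group and not on the shared core. Methoxy in place of amino on an aromatic carbon gives a number 1 percentage points higher from compound 1 to compound 4 (within the scatter), so this assay does not separate these two aryl groups. Nothing available explains the large step.

Still open, as far as these compounds go, is whether a single chlorine, as in 4-chlorophenyl, behaves like 3,4-dichlorophenyl. Also open, from the compounds shown here alone, is how a carboxylic acid or a hydroxy group on this aryl ring would read.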